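The compounds below may be only part of what the source reports. "The series", "measured", "known", "first", "only" and "open" are said of these compounds alone.

In a functional assay on MGC-803 cells (Homo sapiens) for antiproliferative activity, read by MTT assay, with a stated time of 72 h (on this read-out lower numbers stand for stronger inhibition and higher numbers for weaker inhibition), compound 1 (`O=C(NO)c1ccc(NCc2nc(-c3ccccc3)nn2-c2cccc(Cl)c2)cc1`) gives 13700 nM and compound 2 (`Cc1cccc(-c2nc(CNc3ccc(C(=O)NO)cc3)n(-c3ccccc3)n2)c1`) gives 8710 nM and these two numbers lie within the scatter of each other. Among the measured compounds shown here, compound 1 therefore stands level with the only other measured compound, and the pair cannot be ranked. For the measured compounds named here, the two differ in more than one place, so the data offer no measured step from a single change.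

Compound 3 (`O=C(NO)c1ccc(NCc2nc(-c3ccccc3)nn2-c2ccccc2Cl)cc1`) keeps the core of compound 1 and carries 2-chlorophenyl in place of 3-chlorophenyl on an aromatic nitrogen. Going by the values given here, the data hold no measured example of this change, so the expectation rests only on how closely compound 1 and compound 2 agree. No step beyond the scatter is expected in this assay, with at most a slight lean toward a lower number. The estimated step (a 1.2-fold lower number from compound 1 to compound 3 (0.10 log units; within the scatter)) reflects that small expectation. Compound 3 is expected at 11000 nM (estimated range 4500 nM to 27000 nM).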

Compound 3, half-maximal inhibitory concentration: 9630 nM
Compound 3: middle estimate off by 1.1-fold (0.06 log units), on the high side, within the range that was stated.
By their numbers in this assay, from the lowest: compounds 2, 3 and 1 (each within the scatter of the next).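

Among the compounds shown here, on the aromatic nitrogen of the five-membered ring, the single change from 3-chlorophenyl to 2-chlorophenyl gives, in this assay, a 1.4-fold lower number from compound 1 to compound 3 (0.15 log units; within the scatter) and is the first measured step. For the compounds shown here, until now, the only comparison available was between two compounds differing in more than one place, whereas this pair isolates the placement of the chlorine on the phenyl group, and the two placements cannot be told apart in this assay, with compound 3 at 9630 nM and the rest of the structure unchanged. Nothing in the available data accounts for this result or says what lies behind it.

The compounds shown leave open whether a different group on this aromatic nitrogen, such as a pyridyl ring, a benzyl group or a methoxy-bearing phenyl group, would move the number beyond the scatter. They also leave open whether a change elsewhere, such as a carboxylic acid in place of the group at the end of the benzene ring or an amine on the phenyl group of the neighbouring ring atom, would do so.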